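Swapping propylsulfanyl for isopropylamino on the shared core

A few compounds are considered here, and "the series" means these few. Any claim that something is new, unique, unknown or untested is made for them only; others in the source may bear on it.

In an ADME assay on HFF cells (Homo sapiens) for cytotoxicity, with a stated time of 8 days (on this read-out higher numbers stand for lower toxicity in this test and lower numbers for higher toxicity in this test), compound 1 `CNc1nc(N)nc2c1ncn2/C=C1/CC1(CO)CO` gives 265000 nM as a measured number. Compound 2 `CCCSc1nc(N)nc2c1ncn2/C=C1/CC1(CO)CO` gives > 300000 nM as a limit of the assay and not a number. Compound 3 `CC(C)Nc1nc(N)nc2c1ncn2/C=C1/CC1(CO)CO` differs from compound 2 by isopropylamino in place of propylsulfanyl on an aromatic carbon with isopropylamino in place of propylsulfanyl on an aromatic carbon. Within the data shown here, the one measured step bearing on this is an at least 1.1-fold higher number from compound 1 to compound 2 (0.05 log units; that floor lies within the scatter) for the opposite kind of exchange, propylsulfanyl in place of methylamino, so no step beyond the scatter is expected in this assay here. The expected step is an at least 1.2-fold lower number from compound 2 to compound 3 (0.07 log units; that floor lies within the scatter) on this estimate. Compound 3 is estimated at 250000 nM within a range of 120000 nM to 300000 nM in this read-out.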

Compound 3, half-maximal cytotoxic concentration: > 300000 nM
Compound 3 gave a limit, no number; the forecaster's own chance of this, stated with the estimate: 40%; middle value at least 1.2-fold (0.07 log units) from the limit.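

In this assay, the limit is not confined to the propylsulfanyl group: isopropylamino on this aromatic carbon reaches it too. With isopropyl in place of methyl on the nitrogen, the data give an at least 1.1-fold higher number from compound 1 to compound 3 (0.05 log units; that floor lies within the scatter). The exchange of propylsulfanyl for isopropylamino cannot be read because compound 2 and compound 3 sit at the same limit of the assay: the limit of > 300000 nM in this assay, at which 2 of the 3 values shown sit.

Still open, as far as these compounds go, is whether any group on this carbon gives a clearly lower number in this test. A carboxylic acid, a longer alkylamino chain or a cyclic amine would address this.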